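The source may report more compounds than this note shows. Statements on the series, on what has been measured and on what is new or still open speak of the compounds shown alone.

Three compounds share one core and differ only in the chain on the sulfonyl side. In a functional assay, read by fluorescence and spectrophotometry, with a stated time of 1 h (a higher number here means that more compound is needed for the effect, a lower number that less compound is needed), compound 1 `CCCCCCCCCCS(=O)(=O)/C=C/c1ccc(O)c(O)c1` gives 6800 nM, compound 2 `O=S(=O)(/C=C/c1ccc(O)c(O)c1)CCCc1ccccc1` gives 11500 nM, and compound 3 `C=CCCCCCCCS(=O)(=O)/C=C/c1ccc(O)c(O)c1` gives 6900 nM. Compound 3 thus holds the second highest of the three numbers, though both gaps lie within the scatter: a 1.0-fold higher number from compound 1 to compound 3 (0.01 log units; within the scatter) and a 1.7-fold lower number from compound 2 to compound 3 (0.22 log units; within the scatter). Compound 4 `O=S(=O)(/C=C/c1ccc(O)c(O)c1)CCCCCCCO` has not been measured; it differs from compound 3 by hydroxy in place of vinyl on a saturated chain carbon, seven bonds along the chain from a sulfonyl sulfur. Within the data shown here, the closest precedent is the exchange at the same chain position, a 1.0-fold higher number from compound 1 to compound 3 (0.01 log units; within the scatter), which moved nothing beyond the scatter, and a 1.7-fold higher number from compound 1 to compound 2 (0.23 log units; within the scatter) was likewise within it. No shift beyond the scatter is therefore expected, a 1.2-fold higher number from compound 3 to compound 4 (0.06 log units; within the scatter). Compound 4 is estimated at 8000 nM, with a range from 3500 nM to 20000 nM.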

Compound 4, half-maximal effective concentration: 5900 nM
Compound 4: middle estimate off by 1.4-fold (0.13 log units), on the high side; the range from low to high includes it.
By their numbers in this assay, from the lowest: compounds 4, 1, 3 and 2 (each within the scatter of the next).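

In this assay, hydroxy brings one hydrogen-bond donor and one hydrogen-bond acceptor to this place on the chain, seven bonds along from a sulfonyl sulfur, yet the step stays within the scatter (a 1.2-fold lower number from compound 3 to compound 4 (0.07 log units; within the scatter)). The same holds against the saturated chain of compound 1 (a 1.2-fold lower number from compound 1 to compound 4 (0.06 log units; within the scatter)) and the phenyl-ended chain of compound 2 (a 1.9-fold lower number from compound 2 to compound 4 (0.29 log units; within the scatter)). Nothing available gives a reason for this result. Going by these compounds, whether an amine or a carboxylic acid at this chain end, or a longer chain ending in hydroxy, would step beyond the scatter remains open.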